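A few compounds are considered here, and "the series" means these few. Any claim that something is new, unique, unknown or untested is made for them only; others in the source may bear on it.

Compound 3 `CCc1ccc2c(c1)[n+]([O-])c(NCCN(C)C)n[n+]2[O-]` carries an ethyl group on the shared core. In a physicochemical assay for solubility, in the presence of a further agent that is not named here (on this read-out lower numbers stand for lower solubility and higher numbers for higher solubility), compound 3 gives only a limit of the assay, > 49000000 nM. Compound 2 `Cc1ccc2c(c1)[n+]([O-])c(NCCN(C)C)n[n+]2[O-]` in this assay likewise gives a limit, > 51000000 nM. Compound 1 `CN(C)CCNc1n[n+]([O-])c2ccccc2[n+]1[O-]` in this assay gives 50000000 nM. Compound 4 `CC(C)c1ccc2c(c1)[n+]([O-])c(NCCN(C)C)n[n+]2[O-]` is not yet measured; its change from compound 3 is methyl in place of hydrogen on a saturated chain carbon bound to an aromatic carbon and a saturated chain carbon. The measured steps that bear on this change are an at least 1.0-fold higher number from compound 1 to compound 2 (0.00 log units; that floor lies within the scatter), a step that the limit leaves unreadable from compound 1 to compound 3 and a step that the two limits leave unreadable from compound 2 to compound 3. Because two of the three values sit at limits, the limit of > 49000000 nM in this assay, at which 1 of the 3 values shown sits, and (the limit of > 51000000 nM in this assay, at which 1 of the 3 values shown sits), no step size can be read, and no step beyond the scatter is expected here. The step expected in this assay is a step that the limit leaves unreadable from compound 3 to compound 4. For compound 4 the estimate is 50000000 nM, within 25000000 nM to 100000000 nM.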

Compound 4, solubility: 42000000 nM
Estimate against measurement, compound 4: 1.2-fold (0.08 log units) above; measured number inside the range.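

In this assay the isopropyl compound 4 gives a true number with a group at this place, where compounds 2 and 3 give only limits. Going by these compounds alone, the one full step is a 1.2-fold lower number from compound 1 to compound 4 (0.08 log units; within the scatter) for isopropyl in place of hydrogen. The other two are only floors, an at least 1.1-fold lower number from compound 3 to compound 4 (0.06 log units; that floor lies within the scatter) and an at least 1.2-fold lower number from compound 2 to compound 4 (0.08 log units; that floor lies within the scatter) for these changes, so neither shows a step beyond the scatter.

On these data alone, the steps ending at compound 3 cannot be read, and the true size of both floors stays open. As far as these compounds go, how a longer chain or an amine would read at this place also stays open.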